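Chloro for nitro on the benzyl arm of the core

The compounds below may be only part of what the source reports. "The series", "measured", "known", "first", "only" and "open" are said of these compounds alone.

Compound 3 `O=c1ccoc2cc(OCc3cn(Cc4cccc([N+](=O)[O-])c4)nn3)ccc12` is the point of departure. Within the data shown here, in a functional assay on HeLa cells (Homo sapiens) for cytotoxicity, read by MTT assay, with a stated time of 48 h (a higher number here means a weaker inhibitor, a lower number a stronger inhibitor), compound 3 gives 17300 nM, the second highest of the three numbers so far. Its nearest neighbour is compound 2 `O=c1ccoc2cc(OCc3cn(Cc4ccccc4Br)nn3)ccc12`, which in this assay gives 14500 nM. Its furthest is compound 1 `O=c1ccoc2cc(OCc3cn(Cc4ccc([N+](=O)[O-])cc4)nn3)ccc12`, which in this assay gives 25700 nM. None of the three is separated from the others beyond the scatter: a 1.8-fold lower number from compound 1 to compound 2 (0.25 log units; within the scatter), a 1.5-fold lower number from compound 1 to compound 3 (0.17 log units; within the scatter), a 1.2-fold higher number from compound 2 to compound 3 (0.08 log units; within the scatter).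

Compound 4 `O=c1ccoc2cc(OCc3cn(Cc4cccc(Cl)c4)nn3)ccc12` has not been measured. It differs from compound 3 by chloro in place of nitro on an aromatic carbon. Among the measured compounds shown here, no measured step exchanges nitro for chloro. The step that bears most closely on it is a 1.8-fold lower number from compound 1 to compound 2 (0.25 log units; within the scatter), where a bromo-bearing ring took the place of a nitro-bearing ring and the number stayed within the scatter; compound 3 and compound 1, both carrying nitrophenyl, likewise stayed within the scatter of compound 2. Nothing in the series therefore points to a step beyond the scatter in this assay, in either direction. Compound 4 is expected at 15000 nM, with a range of 7000 nM to 32000 nM. The expected step is a 1.2-fold lower number from compound 3 to compound 4 (0.06 log units; within the scatter).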

Compound 4, half-maximal inhibitory concentration: > 100000 nM
Compound 4 gave a limit, no number (the forecaster's own chance of this, stated with the estimate: 10%); at least 6.6-fold (0.82 log units) between middle value and limit.
By their numbers in this assay, from the lowest: compounds 2, 3 and 1 (each within the scatter of the next). At a limit, above all of these: compound 4.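

In this assay compound 4 gives a limit, not a number: the limit of > 100000 nM in this assay, at which 1 of the 4 values shown sits. Chloro in place of nitro at this position is the first change in the series to go beyond the scatter, with an at least 5.7-fold higher number from compound 3 to compound 4 (0.76 log units; beyond the scatter). The other two comparisons agree, with an at least 6.8-fold higher number from compound 2 to compound 4 (0.83 log units; beyond the scatter) and an at least 3.8-fold higher number from compound 1 to compound 4 (0.59 log units; beyond the scatter), whereas the 2-bromophenyl, 3-nitrophenyl and 4-nitrophenyl compounds all lie within the scatter of one another, so the benzyl arm is not indifferent to what it carries.

As far as these compounds go, how far compound 4 lies past its limit stays open. Also open, from the compounds shown here alone, is whether the change belongs to chloro alone: bromo, an amine or a carboxylic acid in the same place on the ring would tell.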